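Aryl Change on the Chain: Expectation for Compound 3

A few compounds are considered here, and "the series" means these few. Any claim that something is new, unique, unknown or untested is made for them only; others in the source may bear on it.

Measured compounds:
Compound 1 `COc1ccc(/C=C/C(=O)Nc2cc(C(=O)c3cc(OC)c(OC)c(OC)c3)ccc2OC)cc1` gives 12800 nM in a functional assay on DU-145 cells (Homo sapiens) for cytotoxicity, read by MTT assay, with a stated time of 72 h; on this read-out higher numbers stand for weaker inhibition and lower numbers for stronger inhibition.
Compound 2 `COc1cc(/C=C/C(=O)Nc2cc(C(=O)c3cc(OC)c(OC)c(OC)c3)ccc2OC)ccc1F` gives 12100 nM in this assay.

In this assay compound 2 gives 12100 nM, and compound 1 gives 12800 nM; the two lie within the scatter of each other. Compound 3 `COc1ccc(C(=O)c2cc(OC)c(OC)c(OC)c2)cc1NC(=O)/C=C/c1cccc(OC(F)(F)F)c1` differs from compound 2 by 3-(trifluoromethoxy)phenyl in place of 4-fluoro-3-methoxyphenyl on a double-bonded chain carbon bound to a double-bonded chain carbon. Among the compounds with values here, the one measured step at that place, a 1.1-fold lower number from compound 1 to compound 2 (0.02 log units; within the scatter), was within the scatter, so the aryl group on the chain carbon has so far moved the number little. Accordingly the expected step is a 1.0-fold lower number from compound 2 to compound 3 (0.00 log units; within the scatter), none beyond the scatter. Compound 3 is therefore estimated at 12000 nM, with a range from 5000 nM to 30000 nM.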

Compound 3, half-maximal inhibitory concentration: 10200 nM
Compound 3: the middle estimate sits 1.2-fold (0.07 log units) above what was measured, and the stated range covers the measured number.
By their numbers in this assay, from the lowest: compounds 3, 2 and 1 (each within the scatter of the next).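

In this assay, 3-(trifluoromethoxy)phenyl on the double-bonded chain carbon stays within the scatter of both earlier aryl groups (a 1.2-fold lower number from compound 2 to compound 3 (0.07 log units; within the scatter)) and (a 1.3-fold lower number from compound 1 to compound 3 (0.10 log units; within the scatter)). Within the data shown here, all three aryl groups at this place therefore lie within the scatter of one another, even with three fluorine atoms in the entering group, so no step at this position has yet gone beyond it. No measurement available here bears on why this is so. The compounds leave open whether an amine or a carboxylic acid on this aryl ring would move the number beyond the scatter.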